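This account rests on a few compounds, and the source may have more. Where it says the series, first, only, none or still open, it means among the compounds named here.

Measured compounds:
Compound 1, `ClCc1ccc(Cn2cnc3c(Cl)ncnc32)cc1`, 21900 nM in a functional assay on SNB-19 cells (Homo sapiens) for cytotoxicity, read by sulforhodamine B assay, with a stated time of 48 h; a higher number here means a weaker inhibitor of growth, a lower number a stronger inhibitor of growth.
Compound 2, `ClCc1ccccc1Cn1cnc2c(Cl)nc(Cl)nc21`, "not determined" (no result reported) in this assay.

Compound 2 stands without a number: no value is known for it in this assay, so there is no point from which a step to compound 3 can be measured. Compound 3, `ClCc1ccccc1Cn1cnc2c(Cl)ncnc21`, is to be tested. It differs from compound 2 by hydrogen in place of chloro on an aromatic carbon. Since compound 2 has no value, no size can be given for the step from compound 2 to compound 3; the only measured point in this set is compound 1, which gives 21900 nM in this assay. On that single anchor, compound 3 is expected to land at a concentration in the same weak region, 22000 nM, with a range from 6000 nM to 80000 nM.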

Compound 3, concentration for total growth inhibition: > 100000 nM
Compound 3: no number, only a limit; the forecaster's own chance of this, stated with the estimate: 30%; at least 4.5-fold (0.65 log units) between middle value and limit.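

Compound 3 gives > 100000 nM in this assay, which is a limit of the assay and not a number. Among these compounds, with no number for compound 2 either, no step from compound 2 to compound 3 can be read. On these data alone, what swapping that chloro for hydrogen does to growth inhibition stays open.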